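Chloromethylbenzyl purines: amino for chloro on the six-membered ring

A few compounds are considered here, and "the series" means these few. Any claim that something is new, unique, unknown or untested is made for them only; others in the source may bear on it.

Measured so far in a functional assay on A498 cells (Homo sapiens) for cytotoxicity, read by sulforhodamine B assay, with a stated time of 48 h; a lower number here means a stronger inhibitor of growth, a higher number a weaker inhibitor of growth:
compound 1 `ClCc1ccccc1Cn1cnc2c(Cl)nc(Cl)nc21` gives 4780 nM
compound 2 `ClCc1cccc(Cn2cnc3c(Cl)nc(Cl)nc32)c1` gives 6600 nM
compound 3 `Nc1nc(Cl)c2ncn(Cc3ccccc3CCl)c2n1` gives 44700 nM

Compound 1 and compound 2 carry the same atoms joined differently; the difference between the two cores is not broken down here. Their values in this assay sit within the scatter of each other, so no order is drawn from them.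

Compound 3 arises from compound 1 by one change, (amino in place of chloro on an aromatic carbon). This step gave a 9.4-fold higher number from compound 1 to compound 3 (0.97 log units; beyond the scatter), a modest weakening of growth inhibition.

Compound 4 `Nc1nc(Cl)c2ncn(Cc3cccc(CCl)c3)c2n1` is not yet measured in this assay. It arises from compound 2 by amino in place of chloro on an aromatic carbon. The place description for this change is word for word the same as for the change from compound 1 to compound 3, so it is treated as the same change, seen twice in all among the compounds shown.

Among the measured compounds shown here, the expectation for compound 4 rests on the single measured instance of this change: because compound 1 to compound 3 gave a 9.4-fold higher number from compound 1 to compound 3 (0.97 log units; beyond the scatter), a step of similar size is expected from compound 2, namely an 8.3-fold higher number from compound 2 to compound 4 (0.92 log units; beyond the scatter). For the measured compounds named here, with only one earlier example, the range kept around the estimate is wide. Compound 4 is expected to give 55000 nM in this assay, with a range from 20000 nM to 150000 nM.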

Compound 4, concentration for total growth inhibition: 51300 nM
Compound 4: the middle estimate sits 1.1-fold (0.03 log units) above what was measured; low and high end bracket the measured number.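

In this assay, amino in place of chloro on an aromatic carbon again weakens growth inhibition, with a 7.8-fold higher number from compound 2 to compound 4 (0.89 log units; beyond the scatter). Set beside the earlier step, the change carries from one core to the other at much the same size: the same change on two cores in this assay, a 9.4-fold higher number (0.97 log units; beyond the scatter) from compound 1 to compound 3 and a 7.8-fold higher number (0.89 log units; beyond the scatter) from compound 2 to compound 4, 1.2-fold (0.08 log units) apart, within the scatter of two such steps. Among the compounds shown here, this agreement rests on only two cores that carry the same atoms joined differently, so it shows transfer within this narrow pair and gives neither a general rule for other cores nor a reason for the loss of growth inhibition.

The compounds shown compare amino only with chloro at this carbon, so it remains open whether a substituted amine such as dimethylamino, or a methoxy group, would give a step of similar size on either core. Also open, on these data alone, is what happens to these steps when the chloromethyl group gives way to another group, such as hydroxymethyl, and whether the same change at the other chloro group, the one meta to the ring carbon that carries the amino group in compound 3 and compound 4, would behave alike.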